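Compound 3: a new amino group on the carbonyl

A few compounds are considered here, and "the series" means these few. Any claim that something is new, unique, unknown or untested is made for them only; others in the source may bear on it.

Measured in a physicochemical assay for pharmacokinetics; on this read-out higher numbers stand for a longer-lived compound and lower numbers for a shorter-lived compound:
- compound 1 `O=C(NCc1cccc2ccccc12)N1C(=O)c2ccccc2S1(=O)=O`: > 166 h
- compound 2 `O=C(c1ccccc1)N1C(=O)c2ccccc2S1(=O)=O`: > 166 h

Both readings are limits, not numbers. Compound 2 therefore stands at the limit of > 166 h in this assay, at which 2 of the 2 values shown sit. Compound 3 `O=C(NCc1cccs1)N1C(=O)c2ccccc2S1(=O)=O` differs from it as follows: ((thiophen-2-yl)methyl)amino in place of phenyl on a carbonyl carbon. In words, ((thiophen-2-yl)methyl)amino stands in place of phenyl on a carbonyl carbon. No measured step sizes this change in this assay. Compound 1 reads > 166 h, also a limit, so no step beyond the scatter is expected. The estimated step is a step that the limit leaves unreadable from compound 2 to compound 3. The expected value for compound 3 is 200 h, with an estimated range of 120 h to 400 h.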

Compound 3, half-life: > 166 h
Compound 3 was reported as a limit (the forecaster's own chance of this, stated with the estimate: 80%); the middle value does not contradict the limit.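

In this assay no step can be read between compound 2 and compound 3, since both readings are limits: the limit of > 166 h in this assay, at which 3 of the 3 values shown sit.

The compounds shown leave open whether ((thiophen-2-yl)methyl)amino in place of phenyl on a carbonyl carbon changes the half-life at all.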